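The source may report more compounds than this note shows. Statements on the series, on what has been measured and on what is new or still open speak of the compounds shown alone.

Compound 2 `N#Cc1ccc(/C=C/c2nc3ncccc3[nH]2)cc1` gives 86600 nM in a functional assay on SK-BR-3 cells (Homo sapiens) for antiproliferative activity, read by MTT assay, with a stated time of 72 h (a higher number here means a weaker inhibitor, a lower number a stronger inhibitor), the highest of the two numbers in hand. Its nearest neighbour is compound 1 `C(=C/c1nc2ncccc2[nH]1)\c1ccccc1`, which in this assay gives 2060 nM. Among the compounds with values here, the only step recorded between measured compounds is a 42-fold higher number from compound 1 to compound 2 (1.62 log units; beyond the scatter), and that step concerns the cyano group on the phenyl ring, not the fused core shared by both compounds. Compound 3 `N#Cc1ccc(/C=C/c2nc3ncc(Br)cc3[nH]2)cc1` differs from compound 2 by bromo in place of hydrogen on an aromatic carbon. Within the data shown here, no measured step touches that position of the fused core, so nothing in hand speaks for a change in either direction in this assay; the large step seen between compound 1 and compound 2 lies on the other ring and offers no guide here. The expectation is therefore a step of a 1.1-fold lower number from compound 2 to compound 3 (0.03 log units; within the scatter), which is within the scatter. On this basis compound 3 is expected to give about 80000 nM in this assay, with a range from 20000 nM to 300000 nM, the breadth of that range reflecting that the change has no measured precedent among these compounds.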

Compound 3, half-maximal inhibitory concentration: 4310 nM
Compound 3: the middle estimate sits 19-fold (1.27 log units) above what was measured, outside the stated range (below it).
By their numbers in this assay, from the lowest: compound 1; then compound 3; then compound 2.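

Within the data shown here, on the shared core, at a carbon of the six-membered aromatic ring with 1 nitrogen, bromo in place of hydrogen moves this assay by a large step (a 20-fold lower number from compound 2 to compound 3 (1.30 log units; beyond the scatter)), so this position matters in a way the earlier compounds could not reveal. Among these compounds, the only step known before lay on the phenyl ring and ran the other way (a 42-fold higher number from compound 1 to compound 2 (1.62 log units; beyond the scatter)), which shows that the number can be moved strongly in either direction from two separate parts of the molecule, and that a single added bromine atom is enough to do so on the core. Nothing in hand bears on why the number falls with this change.

With only hydrogen and bromo shown at this carbon, it remains open whether the drop belongs to bromo alone or would also follow with a chloro, a methoxy or an amine in the same place. As far as these compounds go, it also remains open whether bromo at this position would lower the number to a similar extent on the core of compound 1, which carries no cyano group on its phenyl ring.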